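The source may hold more compounds than are shown below. What is called first, only, known or untested is meant among the compounds shown, and "the series" means these compounds.

Three measured compounds share one core. Compound 1 `Cc1ccc(C2=NN(C(N)=S)[C@@H](c3ccc(Cl)cc3)C2)cc1` gives 13 nM in an assay on mitochondria for inhibition of Amine oxidase [flavin-containing] A (Bos taurus); a lower number here means a stronger inhibitor, a higher number a weaker inhibitor. Compound 2 `Cc1ccc(C2=NN(C(N)=S)[C@H](c3ccc(Cl)cc3)C2)cc1` has the same atoms and bonds and differs only in the configuration drawn at a saturated ring carbon, and in this assay compound 2 gives 50 nM. Going by the values given here, the step of a 3.8-fold higher number from compound 1 to compound 2 (0.59 log units; beyond the scatter) is the only step here between compounds that differ in a single place, and what sets the two apart is the fact that compounds 1 and 2 differ only in the configuration as drawn. Compound 3 `Cc1ccc(C2=NN(C(N)=S)C(c3ccc(C)cc3)C2)cc1` gives 6 nM. Among the three numbers compound 2 stands highest, nearest to compound 1 and furthest from compound 3.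

Compound 4 `NC(=S)N1N=C(c2ccc(F)cc2)C[C@H]1c1ccc(Cl)cc1` arises from compound 2 through a single change, fluoro in place of methyl on an aromatic carbon, which read one bond further out is 4-methylphenyl to 4-fluorophenyl. Among the compounds with values here, none of the measured steps bears on this change. Within the data shown here, the one step available concerns configuration alone and says nothing about swapping a substituent on an aromatic ring, and compound 3 differs from compound 2 in more than one place, so its value cannot be read as a step. With no measured guide, for compound 4 the expected step of no change at the digits printed from compound 2 to compound 4 (within the scatter) is none beyond the scatter. Compound 4 is therefore estimated at 50 nM, within a range of 20 nM to 130 nM.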

Compound 4, inhibition constant: 6 nM
Beside the measured number, compound 4's estimate is 8.3-fold (0.92 log units) above it, and the stated range ends above it.
By their numbers in this assay, from the lowest: compounds 3 and 4 (each within the scatter of the next); then compound 1; then compound 2.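

In this assay, going by these compounds alone, the replacement of methyl by fluoro on an aromatic carbon, para to a large group, gives the first measured step at this position: an 8.3-fold lower number from compound 2 to compound 4 (0.92 log units; beyond the scatter). Within the data shown here, the earlier compounds had offered only a step in configuration, so this is the first sign that the number responds to what sits at this place on the ring, even though one heavy atom leaves, one enters, and neither group counts a hydrogen-bond donor, a hydrogen-bond acceptor or a net charge. Nothing measured here accounts for why this exchange lowers the number.

Going by these compounds, whether the same change would lower the number to a similar extent with the configuration drawn in compound 1 remains open, since this step was read only with the configuration of compound 2. Also open, on these data alone, is how this position would respond to a chloro, a methoxy or an amine, or to a bare hydrogen. A single step shows the effect of one exchange and not a trend across groups.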